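Removing a Bromo Group from Arylhydrazone Thiazoles

The compounds below may be only part of what the source reports. "The series", "measured", "known", "first", "only" and "open" are said of these compounds alone.

Three compounds were measured in a functional assay on Caco-2 cells (Homo sapiens) for inhibition, read by MTT assay, with a stated time of 48 h; a higher number here means a weaker inhibitor, a lower number a stronger inhibitor. Compound 1 `COc1cc(/C=N/Nc2nc(-c3ccc(C(F)(F)F)cc3)cs2)c(Br)c(Br)c1OC` reaches only a limit of the assay there, > 100000 nM. Compound 2 `Fc1ccc(/C=N/Nc2nc(-c3ccc(Br)cc3)cs2)cc1F` gives 43900 nM in this assay, and compound 3 `Fc1ccc(/C=N/Nc2nc(-c3ccccc3)cs2)cc1F` gives 20900 nM. The change from compound 2 to compound 3 is hydrogen in place of bromo on an aromatic carbon, and it produced a 2.1-fold lower number from compound 2 to compound 3 (0.32 log units; beyond the scatter). Compound 4 `COc1cc(/C=N/Nc2nc(-c3ccc(C(F)(F)F)cc3)cs2)cc(Br)c1OC`, not yet measured, differs from compound 1 by hydrogen in place of bromo on an aromatic carbon. This is the same kind of change, though here the carbon losing its bromo sits ortho to a bromo group, ortho to a large group, meta to a methoxy group and para to a methoxy group, whereas in compound 2 it sits para to a large group. How the cores of compound 1 and compound 2 differ is not broken down here. As far as these compounds go, because compound 1 stands at the limit (the limit of > 100000 nM in this assay, at which 1 of the 3 values shown sits), its starting point is unknown, so the expected step of a number no higher from compound 1 to compound 4 (the limit leaves the size open) rests on the earlier one only loosely. Compound 4 is expected to give about 100000 nM, between 40000 nM and 250000 nM, and may itself return only a limit.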

Compound 4, half-maximal inhibitory concentration: 65900 nM
The estimate for compound 4 lay 1.5-fold (0.18 log units) above the measured number; measured number inside the range.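

Replacing the bromo group with hydrogen on a second core gave an at least 1.5-fold lower number from compound 1 to compound 4 (0.18 log units; that floor lies within the scatter) in this assay, which points the same way as the earlier step, although its floor alone does not go beyond the scatter. The two cores therefore do not show that the change has the same size on each, nor that its size differs: the same change on two cores in this assay, a 2.1-fold lower number (0.32 log units; beyond the scatter) from compound 2 to compound 3 and an at least 1.5-fold lower number (0.18 log units; that floor lies within the scatter) from compound 1 to compound 4; the limit leaves it open whether they differ

With only two cores, this is no rule for the series, and the true size of the new step stays unknown: the limit of > 100000 nM in this assay, at which 1 of the 4 values shown sits.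

As far as these compounds go, it remains open whether a chloro group or an amine in place of the bromo group would shift the number in the same way. From the compounds shown here alone, how the change behaves on other cores also remains open.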